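A Trifluoromethyl Moved Around the Benzyl Ring

A few compounds are considered here, and "the series" means these few. Any claim that something is new, unique, unknown or untested is made for them only; others in the source may bear on it.

Three compounds have so far been measured in a functional assay on A-375 cells (Homo sapiens) for antiproliferative activity, read by MTT assay, with a stated time of 24 h; on this read-out lower numbers stand for stronger inhibition and higher numbers for weaker inhibition:

compound 1, `COc1cc(OC)c(-c2coc3cc(OCc4ccccc4)ccc3c2=O)cc1OC`: 1640 nM
compound 2, `COc1cc(OC)c(-c2coc3cc(OCC(=O)c4cccc(C(F)(F)F)c4)ccc3c2=O)cc1OC`: the assay reports only a limit, > 10000 nM
compound 3, `COc1cc(OC)c(-c2coc3cc(OCc4ccccc4C(F)(F)F)ccc3c2=O)cc1OC`: again only a limit, > 10000 nM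

Compound 1 is therefore the only one of the three with an actual number in this assay; the other two sit at the limit of > 10000 nM in this assay, at which 2 of the 3 values shown sit, a ceiling rather than a measurement, so their true activity is only known to be weaker than that.

Compound 4, `COc1cc(OC)c(-c2coc3cc(OCc4ccc(C(F)(F)F)cc4)ccc3c2=O)cc1OC`, is the next to be tested. Compared with compound 1 the change is trifluoromethyl in place of hydrogen on an aromatic carbon.

Going by the values given here, the closest precedent is the step in which the same trifluoromethyl group entered the same ring at a different carbon: an at least 6.0-fold higher number from compound 1 to compound 3 (0.78 log units; beyond the scatter). Exchanging the benzyl group for a ketone-bearing chain gave an at least 6.0-fold higher number from compound 1 to compound 2 (0.78 log units; beyond the scatter). The comparison between these two weak compounds, a step that the two limits leave unreadable from compound 2 to compound 3, adds nothing usable. Both readable steps point the same way, toward loss of activity whenever this ring is decorated, though a single placement cannot prove that every placement behaves alike.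

The expectation for compound 4 is therefore a weakening, a 4.9-fold higher number from compound 1 to compound 4 (0.69 log units; beyond the scatter), in this assay. Compound 4 is estimated at 8000 nM, most likely between 2500 nM and 20000 nM, with a real chance that only a limit is reported.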

Compound 4, half-maximal inhibitory concentration: 2280 nM
Compound 4: middle estimate off by 3.5-fold (0.55 log units), on the high side; the measured number lies below the stated range.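

In this assay, the 4-(trifluoromethyl)benzyl group is tolerated in place of benzyl: the change gives a 1.4-fold higher number from compound 1 to compound 4 (0.14 log units; within the scatter), so these two compounds cannot be told apart. Adding trifluoromethyl to this ring therefore does not always weaken the compound, and its placement matters, as the change from 2-(trifluoromethyl)phenyl to 4-(trifluoromethyl)phenyl gives an at least 4.3-fold lower number from compound 3 to compound 4 (0.64 log units; beyond the scatter), while replacing the ketone-bearing chain with the 4-(trifluoromethyl)benzyl group gives an at least 4.3-fold lower number from compound 2 to compound 4 (0.64 log units; beyond the scatter). Compound 2 and compound 3 each carry only a limit, so these two steps give a minimum size and the step between those two compounds cannot be read: the limit of > 10000 nM in this assay, at which 2 of the 4 values shown sit.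

Compound 2 differs from compound 4 in both its carbonyl and its 3-(trifluoromethyl)phenyl ring, so the compounds shown leave open which of these features accounts for the step. They also leave open whether a chlorine or an amine on the same ring carbon would match trifluoromethyl, and so whether the result is specific to trifluoromethyl or extends to other groups at that carbon.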